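The source may hold more compounds than are shown below. What is called first, only, known or untested is meant among the compounds shown, and "the series" means these compounds.

Measured so far:

compound 1 `COc1ccc(C(=O)N2CCN(CC(=O)N3CCN(CCCc4c[nH]c5ccccc45)CC3)CC2)cc1` with 148000 nM
compound 2 `O=C(CN1CCN(C(=O)c2ccc(Br)cc2)CC1)N1CCN(CCCc2c[nH]c3ccccc23)CC1` with 59300 nM
compound 3 `COc1cccc(C(=O)N2CCN(CC(=O)N3CCN(CCCc4c[nH]c5ccc(OC)cc45)CC3)CC2)c1`

Compound 1 and compound 2 share a core and differ in one place; in an ADME assay on SH-SY5Y cells (Homo sapiens) for cytotoxicity, read by MTT assay, with a stated time of 72 h (a lower number here means a stronger inhibitor, a higher number a weaker inhibitor), compound 1 gives 148000 nM and compound 2 gives 59300 nM. The change between them is bromo in place of methoxy on an aromatic carbon, and the step it made is a 2.5-fold lower number from compound 1 to compound 2 (0.40 log units; beyond the scatter).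

Compound 3 stands on a different core from compound 1; the difference between the two cores is not broken down here. In this assay, among the compounds with values here, compound 3 gives only a limit, > 200000 nM, and no number; it is the one value sitting at the limit of > 200000 nM in this assay, at which 1 of the 3 values shown sits.

Compound 4 `COc1ccc2[nH]cc(CCCN3CCN(C(=O)CN4CCN(C(=O)c5cccc(Br)c5)CC4)CC3)c2c1` is not yet measured. It differs from compound 3 by bromo in place of methoxy on an aromatic carbon. Within the data shown here, this is the same kind of change as the one from compound 1 to compound 2, not the same: there the place is para to a large group, here it is meta to a large group.

For compound 4 in this assay the expectation rests on the step from compound 1 to compound 2, a 2.5-fold lower number from compound 1 to compound 2 (0.40 log units; beyond the scatter), applied from a starting point that is only a limit; the expected step is an at least 1.6-fold lower number from compound 3 to compound 4 (0.22 log units; that floor lies within the scatter), and the estimate for compound 4 is 120000 nM, between 50000 nM and 300000 nM. Because compound 3 gives only the limit > 200000 nM, compound 4 may also return a limit rather than a number.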

Compound 4, half-maximal inhibitory concentration: 105000 nM
Estimate against measurement, compound 4: 1.1-fold (0.06 log units) above; measured number inside the range.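

In this assay, bromo in place of methoxy on the core of compound 3, on an aromatic carbon meta to a large group, gives an at least 1.9-fold lower number from compound 3 to compound 4 (0.27 log units; that floor lies within the scatter). Compound 3 gives only a limit, > 200000 nM, and not a number. Set beside the earlier step, the change runs in the same direction on both cores, but this pair does not show that its size carries over from one core to the other, and the place of the change on the ring also differs between the two pairs: the same change on two cores in this assay, a 2.5-fold lower number (0.40 log units; beyond the scatter) from compound 1 to compound 2 and an at least 1.9-fold lower number (0.27 log units; that floor lies within the scatter) from compound 3 to compound 4; the limit leaves it open whether they differ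

Still open, on these data alone, is how the change reads when the two cores carry it at one and the same place on the ring, and how large the step on the core of compound 3 is once the methoxy side has a number in place of a limit. Also open, as far as these compounds go, is whether other groups at this place, such as an amine, a carboxylic acid or a nitrile, would move the number in this assay in the same direction as bromo does on these two cores.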